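A Fluoro Step from Compound 1 to Compound 3

The compounds below may be only part of what the source reports. "The series", "measured", "known", "first", "only" and "open" are said of these compounds alone.

Measured in a functional assay on Vero cells (Chlorocebus sabaeus) for inhibition; on this read-out higher numbers stand for weaker inhibition and lower numbers for stronger inhibition:
- compound 1 `Nc1ncnc2c1ncn2[C@@H]1O[C@@H](CO)C=C1F`: > 100000 nM
- compound 2 `OC[C@H]1C=C(F)[C@H](n2cnc3c(O)ncnc32)O1`: > 100000 nM

Compound 1 stands only at a limit: in this assay compound 1 gives > 100000 nM, which is a limit and not a number. Compound 2 gives > 100000 nM, which is also a limit. Together they form (the limit of > 100000 nM in this assay, at which 2 of the 2 values shown sit). Among the measured compounds shown here, the one measured step, hydroxy in place of amino on an aromatic carbon, is a step that the two limits leave unreadable from compound 1 to compound 2.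

Compound 3 `Nc1nc(F)nc2c1ncn2[C@@H]1O[C@@H](CO)C=C1F` differs from compound 1 by fluoro in place of hydrogen on an aromatic carbon. The measured step offers no size to carry over to this change. Only a modest move towards stronger inhibition in this assay is expected, if any, and a further limit is quite possible. The expected change is an at least 1.4-fold lower number from compound 1 to compound 3 (0.15 log units; that floor lies within the scatter). For compound 3 the estimated value is 70000 nM, with an expected range from 15000 nM to 200000 nM.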

Compound 3, half-maximal inhibitory concentration: > 100000 nM
Compound 3 gave a limit, no number (the forecaster's own chance of this, stated with the estimate: 60%); middle value at least 1.4-fold (0.15 log units) away from the limit.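

In this assay, no size can be read for the step from compound 1 to compound 3, and the same holds for the step from compound 1 to compound 2, as all three compounds stand at one limit: the limit of > 100000 nM in this assay, at which 3 of the 3 values shown sit.

The compounds shown leave open whether fluoro in place of hydrogen on an aromatic carbon, or hydroxy in place of amino, alters inhibition at all.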